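The source may hold more compounds than are shown below. What is called first, only, known or untested is meant among the compounds shown, and "the series" means these compounds.

Working notes on the series. Compound 1 `COc1ncc(-c2ccc3ncnc(Nc4ccc(OCCO)cc4)c3c2)cc1NS(C)(=O)=O` gives in a functional assay on HCT-116 cells (Homo sapiens) for antiproliferative activity, read by sulforhodamine B assay, with a stated time of 72 h (on this read-out higher numbers stand for weaker inhibition and lower numbers for stronger inhibition), a value of 4860 nM. Within the data shown here, compound 3 `COc1ncc(-c2ccc3ncnc(Nc4cnn(CCC(=O)O)c4)c3c2)cc1NS(C)(=O)=O` gives in this assay a value of 1290 nM, and the step of a 3.8-fold lower number from compound 1 to compound 3 (0.58 log units; beyond the scatter) is the only measured exchange of the group on the nitrogen on the aromatic ring. Compound 2 `COc1ncc(-c2ccc3ncnc(Nc4cnn(CC(=O)O)c4)c3c2)cc1NS(=O)(=O)c1ccc(F)cc1F` gives in this assay a value of 1540 nM, the second highest of the three numbers; it lies within the scatter of compound 3 and beyond the scatter under compound 1.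

Compound 4 `COc1ncc(-c2ccc3ncnc(Nc4ccc(OCCO)nc4)c3c2)cc1NS(=O)(=O)c1ccc(F)cc1F` is not yet measured. The change from compound 2 is 6-(2-hydroxyethoxy)pyridin-3-yl in place of 1-(carboxymethyl)-1H-pyrazol-4-yl on a nitrogen on an aromatic ring. Among the measured compounds shown here, no measured step repeats this exchange. The step of a 3.8-fold lower number from compound 1 to compound 3 (0.58 log units; beyond the scatter) is the one that bears on it: there a pyrazolyl group carrying a carboxy chain entered in place of a six-membered ring carrying a 2-hydroxyethoxy chain and the number fell. For the measured compounds named here, the change to compound 4 runs that exchange the other way, with a six-membered ring carrying a 2-hydroxyethoxy chain returning; the sulfonamide part is not the one of compound 1, so the carry-over is uncertain. For compound 4 a higher number in this assay is expected, a step of about a 2.9-fold higher number from compound 2 to compound 4 (0.47 log units; beyond the scatter). Compound 4 is therefore estimated at 4500 nM, with a range from 1800 nM to 11000 nM.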

Compound 4, half-maximal inhibitory concentration: 2340 nM
Compound 4: middle estimate off by 1.9-fold (0.28 log units), on the high side, within the range that was stated.
By their numbers in this assay, from the lowest: compounds 3, 2 and 4 (each within the scatter of the next); then compound 1.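

In this assay the step of a 1.5-fold higher number from compound 2 to compound 4 (0.18 log units; within the scatter) shows that, with the sulfonamide part of compound 2, 6-(2-hydroxyethoxy)pyridin-3-yl and 1-(carboxymethyl)-1H-pyrazol-4-yl on a nitrogen on an aromatic ring cannot be told apart beyond the scatter. The earlier exchange, a 3.8-fold lower number from compound 1 to compound 3 (0.58 log units; beyond the scatter), lay beyond the scatter, but it involved other groups and another sulfonamide part, so the size seen there does not recur in this second pair and cannot be taken as a general effect of moving between these two kinds of group. Nothing on hand accounts for the difference between the two steps.

Still open, as far as these compounds go, is whether the sulfonamide part or the exact groups on the nitrogen set the size of such a step, since the two steps share neither. Also open, from the compounds shown here alone, is how this position would read with a morpholine or a primary amine at the end of the chain in place of the hydroxy or carboxy end, on either sulfonamide part.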